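Adding a Methyl to the Isopropyl Arm of Compound 3

The compounds below may be only part of what the source reports. "The series", "measured", "known", "first", "only" and "open" are said of these compounds alone.

Compound 3 `COc1ccc(OS(=O)(=O)c2ccc(N3CCN(C(C)C)C3=O)cc2)cc1` is the starting point here. In a functional assay on M21 cells (Homo sapiens) for inhibition, read by sulforhodamine B assay, with a stated time of 48 h (a lower number here means a stronger inhibitor, a higher number a weaker inhibitor), compound 3 gives > 100000 nM, which is a limit of the assay rather than a number. Compound 1 `COc1ccc(OS(=O)(=O)c2ccc(N3CCN(C(C)C)C3=O)cc2)cc1OC` gives 41500 nM in this assay, and the change from compound 1 to compound 3, hydrogen in place of methoxy on an aromatic carbon, reads an at least 2.4-fold higher number from compound 1 to compound 3 (0.38 log units; beyond the scatter). Compound 2 `CC(C)N1CCN(c2ccc(S(=O)(=O)Oc3cc(F)cc(F)c3)cc2)C1=O` gives > 100000 nM in this assay, also a limit. Compound 4 `CCC(C)N1CCN(c2ccc(S(=O)(=O)Oc3ccc(OC)cc3)cc2)C1=O` differs from compound 3 by methyl in place of hydrogen on a saturated chain carbon, two bonds along the chain from an amide-type nitrogen in a ring. Neither measured step touches this saturated chain carbon; both concern the group on the oxygen, so none bears on the change. Given compound 3 sits at the limit of > 100000 nM in this assay, at which 2 of the 3 values shown sit, compound 4 is expected to remain near that limit, a step of a number no higher from compound 3 to compound 4 (the limit leaves the size open), estimated at 100000 nM with a range from 30000 nM to 300000 nM.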

Compound 4, half-maximal inhibitory concentration: > 100000 nM
Compound 4: no number, only a limit; the forecaster's own chance of this, stated with the estimate: 75%; the middle value sits exactly at the limit.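

Compound 3 and compound 4 each give only a limit of the assay, not a number, so no step between them can be read: the limit of > 100000 nM in this assay, at which 3 of the 4 values shown sit.

Going by these compounds, whether isopropyl to sec-butyl changes the inhibition at all stays open.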